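This account rests on a few compounds, and the source may have more. Where it says the series, first, only, none or still open, it means among the compounds named here.

In a functional assay on WM164 cells (Homo sapiens) for antiproliferative activity, read by sulforhodamine B assay, with a stated time of 48 h (on this read-out lower numbers stand for stronger inhibition and higher numbers for weaker inhibition), compound 1 `CN(C)c1ccc2c(c1)OC(N)=C(C#N)C2c1cccc2c(F)cccc12` gives 220 nM and compound 2 `CN(C)c1ccc2c(c1)OC(N)=C(C#N)C2c1cccc2c(Br)cccc12` gives 220 nM. Compound 3 `COc1ccc(C2C(C#N)=C(N)Oc3cc(N(C)C)ccc32)c2ccccc12` gives 490 nM, the highest of the three numbers and beyond the scatter from both others. Compound 4 `CN(C)c1ccc2c(c1)OC(N)=C(C#N)C2c1ccc(F)c2ccccc12` is still unmeasured. It changes compound 3 by fluoro in place of methoxy on an aromatic carbon, para to a large group: fluoro in place of methoxy on an aromatic carbon. Among the measured compounds shown here, no measured step covers this swap directly. The nearest evidence is no change at the digits printed from compound 1 to compound 2 (within the scatter), where bromo replaces fluoro, and compound 1, which carries its fluoro at a different place, stands at 220 nM. A modest drop is therefore expected, and the expected step is a 1.8-fold lower number from compound 3 to compound 4 (0.24 log units; within the scatter). For compound 4 the estimate is 280 nM, with an expected range of 110 nM to 650 nM.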

Compound 4, half-maximal inhibitory concentration: 470 nM
Beside the measured number, compound 4's estimate is 1.7-fold (0.22 log units) below it; the range from low to high includes it.
By their numbers in this assay, from the lowest: compounds 1 and 2 (each within the scatter of the next); then compounds 4 and 3 (each within the scatter of the next).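

In this assay, the swap gives a 1.0-fold lower number from compound 3 to compound 4 (0.02 log units; within the scatter), so at this carbon, para to a large group, methoxy and fluoro cannot be told apart, although their heavy-atom and hydrogen-bond acceptor counts differ. Fluoro alone does not settle the number: compound 1, with fluoro at a different place, gives 220 nM, while compound 4 gives 470 nM. No measurement here explains why this swap leaves the number in place. Going by these compounds, whether an amine, a hydroxyl or a carboxylic acid at this carbon would behave the same way stays open.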